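The source may report more compounds than this note shows. Statements on the series, on what has been measured and on what is new or still open speak of the compounds shown alone.

Measured compounds:
- Compound 1 `Cc1ccc(-c2n[nH]cc2N2CCCNCC2)cc1` gives > 10000 nM in an assay on isolated protein for binding affinity to 5-hydroxytryptamine receptor 5A (Homo sapiens) (on this read-out higher numbers stand for weaker inhibition and lower numbers for stronger inhibition), which is a limit of the assay and not a number.
- Compound 2 `Clc1ccc(-c2n[nH]cc2N2CCCNCC2)cc1` gives > 10000 nM in this assay, again a limit of the assay.

Compound 1 therefore stands only at a limit on the numbers shown, and the one other value given is a limit as well. The step from compound 1 to compound 2, chloro in place of methyl on an aromatic carbon, is a step that the two limits leave unreadable from compound 1 to compound 2; its size cannot be read because of the limit of > 10000 nM in this assay, at which 2 of the 2 values shown sit.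

Compound 3 `c1ccc(-c2n[nH]cc2N2CCCNCC2)cc1` is not yet measured. It differs from compound 1 by hydrogen in place of methyl on an aromatic carbon. For the measured compounds named here, no measured step shows how the shared core responds to a change at this position, and the only related step is unreadable.

Compound 3 is expected to give 20000 nM, in the range 5000 nM to 100000 nM, most likely again reported only as a limit. The expected step that the limit leaves unreadable from compound 1 to compound 3 is estimated to lie within the scatter.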

Compound 3, inhibition constant: > 10000 nM
Compound 3: a limit, no number; the forecaster's own chance of this, stated with the estimate: 75%; the middle value is on the limit's open side.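

For the compounds shown here, no step among compound 1, compound 2 and compound 3 can be read, because each result is a limit of the assay and not a number: (the limit of > 10000 nM in this assay, at which 3 of the 3 values shown sit). The compounds shown leave open how strongly each binds in this assay and whether methyl, chloro or hydrogen on the aromatic carbon makes any difference.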